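The source may report more compounds than this note shows. Statements on the series, on what has been measured and on what is new or still open speak of the compounds shown alone.

Compound 1, `COc1ccc([C@@H]2CC(=O)c3c(O)cc(OCc4cn(Cc5ccc(C(F)(F)F)cc5)nn4)cc3O2)cc1O`: in a functional assay on RAW264.7 cells (Mus musculus) for inhibition, read by Griess assay, with stated times of 2 h and 24 h (a lower number here means a stronger inhibitor, a higher number a weaker inhibitor), compound 1 gives 17700 nM.
Compound 2, `COc1ccc([C@@H]2CC(=O)c3c(O)cc(OCc4cn(C5CCCC5)nn4)cc3O2)cc1O`: compound 2 gives 10500 nM.
Compound 3, `CCn1cc(COc2cc(O)c3c(c2)O[C@H](c2ccc(OC)c(O)c2)C/C3=N\O)nn1`: compound 3 gives 3140 nM.

Compound 2 holds the second highest of the three numbers; its nearest neighbour is compound 1, within the scatter, and compound 3 sits at a lower number, beyond the scatter, though that pair differs in more than one place. Compound 4, `C#CCOc1cc(O)c2c(c1)O[C@H](c1ccc(OC)c(O)c1)CC2=O`, is not yet measured; it differs from compound 2 by ethynyl in place of 1-cyclopentyl-1H-1,2,3-triazol-4-yl on a saturated chain carbon bound to an oxygen on an aromatic ring. Going by the values given here, the only step at this position, a 1.7-fold lower number from compound 1 to compound 2 (0.23 log units; within the scatter), swapped the group on the triazole and stayed within the scatter; no measured step removes the triazole itself. Compound 4 is therefore expected near compound 2, with a step of a 1.4-fold higher number from compound 2 to compound 4 (0.15 log units; within the scatter) that may well fall within the scatter. The estimate for compound 4 is 15000 nM, ranging from 5000 nM to 50000 nM.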

Compound 4, half-maximal inhibitory concentration: 20900 nM
For compound 4 the middle estimate is 1.4-fold (0.14 log units) below the measured one; measured number inside the range.
By their numbers in this assay, from the lowest: compound 3; then compounds 2, 1 and 4 (each within the scatter of the next).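

In this assay, going by these compounds alone, this is the first step that removes the whole 1-cyclopentyl-1H-1,2,3-triazol-4-yl group at this position, leaving ethynyl on the saturated chain carbon bound to an oxygen on an aromatic ring, and it gives a 2.0-fold higher number from compound 2 to compound 4 (0.30 log units; within the scatter). Replacing 10 heavy atoms and both rings with 2 heavy atoms therefore leaves the two compounds within the scatter, so this assay does not show the triazole to be needed here. Nothing available explains this result. The compounds shown leave open whether an amine or a carboxylic acid on the triazole, or a longer chain in place of propargyl, would shift the number beyond the scatter.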